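Hydroxy in place of bromo on an aromatic carbon

A few compounds are considered here, and "the series" means these few. Any claim that something is new, unique, unknown or untested is made for them only; others in the source may bear on it.

In a functional assay on MOLT-4 cells (Homo sapiens) for inhibition, read by MTT assay, with a stated time of 72 h (a higher number here means a weaker inhibitor, a lower number a stronger inhibitor), compound 1 (`COc1cc(NC(C)CCCNC(=O)NNC(=O)Nc2ccc(Cl)cc2)c2ncccc2c1`) gives 186000 nM as its reading, and compound 2 (`COc1cc(NC(C)CCCNC(=O)NNC(=O)Nc2ccc(C(F)(F)F)cc2)c2ncccc2c1`) gives 24000 nM as its reading. Compound 3 (`COc1cc(NC(C)CCCNC(=O)NNC(=O)Nc2ccc(Br)cc2)c2ncccc2c1`) gives 209000 nM and stands with compound 1 at the weak end of the three, the pair being separated only by a 1.1-fold higher number from compound 1 to compound 3 (0.05 log units; within the scatter) in the data. Compound 2 sits apart, with an 8.7-fold higher number from compound 2 to compound 3 (0.94 log units; beyond the scatter) on that side.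

Compound 4 (`COc1cc(NC(C)CCCNC(=O)NNC(=O)Nc2ccc(O)cc2)c2ncccc2c1`) differs from compound 3 by one change (hydroxy in place of bromo on an aromatic carbon), hydroxy in place of bromo on an aromatic carbon. Among the measured compounds shown here, the steps that bear on it are exchanges at that same place: a 1.1-fold higher number from compound 1 to compound 3 (0.05 log units; within the scatter) for bromo in place of chloro, and a 7.8-fold lower number from compound 1 to compound 2 (0.89 log units; beyond the scatter) for trifluoromethyl in place of chloro. Hydroxy itself has not been measured there, so the guide is indirect. With compound 3 lying well above compound 2, a move toward a lower number seems more likely than one upward. In this assay the expected 1.9-fold lower number from compound 3 to compound 4 (0.28 log units; within the scatter) is a small step in that direction. Compound 4 is estimated at 110000 nM as a middle value, within an expected range of 30000 nM to 300000 nM overall.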

Compound 4, half-maximal inhibitory concentration: 104000 nM
Beside the measured number, compound 4's estimate is 1.1-fold (0.02 log units) above it; the range from low to high includes it.
By their numbers in this assay, from the lowest: compound 2; then compounds 4, 1 and 3 (each within the scatter of the next).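

Exchanging bromo, with no hydrogen-bond donor or acceptor, for hydroxy, with one of each, gives a 2.0-fold lower number from compound 3 to compound 4 (0.30 log units; within the scatter) in this assay, so this change at the position para to a large group does not move the reading beyond the scatter. Hydroxy also stays within the scatter of chloro, with a 1.8-fold lower number from compound 1 to compound 4 (0.25 log units; within the scatter) as the step, whereas a 4.3-fold higher number from compound 2 to compound 4 (0.64 log units; beyond the scatter) lies beyond it, leaving compound 2 as the only one of the four set apart from the others. Nothing available here bears on why hydroxy reads with the halogens rather than with trifluoromethyl.

The compounds shown leave open where an amine, a nitrile or a carboxylic acid at this position would fall. They also leave open whether the gap between trifluoromethyl and the other three groups would persist with a longer chain.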